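Hydroxyphenyl position change on the dimethoxyphenyl core

The compounds below may be only part of what the source reports. "The series", "measured", "known", "first", "only" and "open" are said of these compounds alone.

Among the compounds with values here, compound 3 `COc1cc(OC)cc(-c2cc3ccccc3c(-c3cccc(O)c3)n2)c1` gives 840 nM in a functional assay on HCT-15 cells (Homo sapiens) for cytotoxicity, read by CCK-8 assay and cell counting, with a stated time of 72 h (a lower number here means a stronger inhibitor, a higher number a weaker inhibitor), the lowest of the three numbers measured so far. Within the data shown here, compound 1 `COc1ccc(-c2cc3ccccc3c(-c3cccc(N)c3)n2)cc1` gives 2350 nM and compound 2 `COc1ccc(-c2cc3ccccc3c(-c3ccc(OC)cc3)n2)cc1` gives 2790 nM; the only single-point step, a 1.2-fold higher number from compound 1 to compound 2 (0.07 log units; within the scatter), stays within the scatter. Compound 4 `COc1cc(OC)cc(-c2cc3ccccc3c(-c3ccc(O)cc3)n2)c1` differs from compound 3 by 4-hydroxyphenyl in place of 3-hydroxyphenyl on an aromatic carbon. Among the measured compounds shown here, no measured step moves a substituent from one position to another on this ring, and the one step available, from compound 1 to compound 2, was flat, so no change beyond the scatter is expected; the expected step is a 1.1-fold higher number from compound 3 to compound 4 (0.03 log units; within the scatter). Compound 4 is therefore estimated at 900 nM in this assay, with a range from 350 nM to 2500 nM.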

Compound 4, half-maximal inhibitory concentration: 2780 nM
Beside the measured number, compound 4's estimate is 3.1-fold (0.49 log units) below it; the measured number lies above the stated range.
By their numbers in this assay, from the lowest: compound 3; then compounds 1, 4 and 2 (each within the scatter of the next).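

With the atoms unchanged, 4-hydroxyphenyl in place of 3-hydroxyphenyl on the shared core gives a 3.3-fold higher number from compound 3 to compound 4 (0.52 log units; beyond the scatter) in this assay. Within the data shown here, this is the first single-place step to lie beyond the scatter, and it shows that where the hydroxyl sits on this ring matters here, unlike the flat a 1.2-fold higher number from compound 1 to compound 2 (0.07 log units; within the scatter). Nothing at hand explains the difference.

On these data alone, whether a carboxylic acid or a hydroxymethyl group would follow the same positional trend remains open. So does whether that trend carries over to the core of compound 1.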